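The source may report more compounds than this note shows. Statements on the series, on what has been measured and on what is new or still open speak of the compounds shown alone.

Measured so far in an assay for inhibition of Thromboxane-A synthase (Homo sapiens), using microsomes; a higher number here means a weaker inhibitor, a lower number a stronger inhibitor:
compound 1 `N#Cc1ccccc1C1OCC(C/C=C\CCC(=O)O)C(c2cccnc2)O1` gives 54 nM
compound 2 `O=C(O)CC/C=C\CC1COC(c2cccc3ccccc23)OC1c1cccnc1` gives 40 nM
compound 3 `CC(C)(Oc1ccccc1)C1OCC(C/C=C\CCC(=O)O)C(c2cccnc2)O1` gives 52 nM

Compound 3 stands second highest of the three numbers in this assay, nearest compound 1 and furthest from compound 2; both gaps are within the scatter, as the steps of a 1.0-fold lower number from compound 1 to compound 3 (0.02 log units; within the scatter) and a 1.3-fold higher number from compound 2 to compound 3 (0.11 log units; within the scatter) show. All three measured compounds share one core and differ only in the group on a saturated ring carbon, and every such swap, including a 1.4-fold lower number from compound 1 to compound 2 (0.13 log units; within the scatter), has stayed within the scatter.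

Compound 4 `Cc1ccc(C#N)c(OC(C)(C)C2OCC(C/C=C\CCC(=O)O)C(c3cccnc3)O2)c1` is the next step from compound 3: 2-cyano-5-methylphenyl in place of phenyl on an oxygen on a saturated carbon. Among the compounds with values here, no measured step changes this outer aryl group, so the nearest guide is the indifference of this assay to the aryl variation seen so far; in particular the step of a 1.4-fold lower number from compound 1 to compound 2 (0.13 log units; within the scatter), where a nitrile-bearing phenyl is exchanged, was flat. Compound 4 is therefore expected to stay within the scatter of compound 3, with an estimated step of a 1.0-fold lower number from compound 3 to compound 4 (0.02 log units; within the scatter) and an estimated value of 50 nM (range 22 nM to 115 nM).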

Compound 4, half-maximal inhibitory concentration: 50 nM
For compound 4 middle estimate and measured number coincide at the digits printed; the measured number falls inside the stated range.
By their numbers in this assay, from the lowest: compounds 2, 4, 3 and 1 (each within the scatter of the next).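

In this assay, the first change shown to the aryl group on an oxygen on a saturated carbon, 2-cyano-5-methylphenyl in place of phenyl, gives a flat result (a 1.0-fold lower number from compound 3 to compound 4 (0.02 log units; within the scatter)). Within the data shown here, this place therefore accepts a nitrile and a methyl together, with one more hydrogen-bond acceptor by count, without leaving the scatter, whereas the earlier steps exchanged the whole group on the saturated ring carbon of the shared core. No supporting measurement bears on why this step is flat.

Among these compounds, the nitrile and the methyl enter together, so their separate contributions cannot be read, and only two aryl groups stand at this place. As far as these compounds go, whether any group here moves the number beyond the scatter stays open, for instance an amine on the aryl group or cyclohexyl in place of it.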